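The source may hold more compounds than are shown below. What is called first, only, known or untested is meant among the compounds shown, and "the series" means these compounds.

Measured in an ADME assay on MT4 cells (Homo sapiens) for cytotoxicity, read by MTT assay, with a stated time of 4 days; on this read-out lower numbers stand for higher toxicity in this test and higher numbers for lower toxicity in this test:

- Compound 1 `COC(=O)c1[nH]cc(C(=O)NCc2ccc(F)cc2)c(=O)c1O` gives 19000 nM
- Compound 2 `O=C(O)c1[nH]cc(C(=O)NCc2ccc(F)cc2)c(=O)c1O` gives > 200000 nM as a limit of the assay

Compound 2 therefore stands only at a limit, without a number of its own. Compound 3 `COCCNC(=O)c1[nH]cc(C(=O)NCc2ccc(F)cc2)c(=O)c1O` is reached from compound 2 by the change ((2-methoxyethyl)amino in place of hydroxy on a carbonyl carbon), which turns carboxy into (2-methoxyethyl)carbamoyl on the same carbonyl carbon. Among the measured compounds shown here, one measured step bears on this place: an at least 10-fold higher number from compound 1 to compound 2 (1.02 log units; beyond the scatter), a large step that freed the carboxy group of compound 1. Compound 3, like compound 1, has no free carboxy, so a sizeable move in the opposite direction, towards lower numbers in this assay, is expected, though the limit leaves its exact size open. The expected change is an at least 5.0-fold lower number from compound 2 to compound 3 (0.69 log units; beyond the scatter) in size. For compound 3 the estimate is 40000 nM, with an expected range from 10000 nM to 150000 nM.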

Compound 3, half-maximal cytotoxic concentration: 16000 nM
Beside the measured number, compound 3's estimate is 2.5-fold (0.40 log units) above it; the measured number falls inside the stated range.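

In this assay the change from carboxy to (2-methoxyethyl)carbamoyl gives an at least 12-fold lower number from compound 2 to compound 3 (1.09 log units; beyond the scatter), so the return from the reading of the free carboxy compound is not tied to the methyl ester of compound 1. An amide on this carbonyl carbon does the same. The exchange of methoxy for (2-methoxyethyl)amino gives a 1.2-fold lower number from compound 1 to compound 3 (0.07 log units; within the scatter), and the two groups cannot be told apart in this test.

Going by these compounds, compound 2 stands at a limit of the assay, so the full size of its step to the amide stays open: the limit of > 200000 nM in this assay, at which 1 of the 3 values shown sits. Also open, on these data alone, is whether a plain ethylamino group, a dimethylamino group or a longer chain carrying no ether oxygen on the same carbonyl carbon would read like compound 3.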